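The compounds below may be only part of what the source reports. "The series", "measured", "known", "first", "only" and "open" are said of these compounds alone.

Measured compounds:
- compound 1 `N/C(=N\NC(=S)N1CCCC1)c1ccc(F)cn1`: 60.6%
- compound 2 `Cc1cccc(/C(N)=N/NC(=S)N2CCOCC2)n1`: 57.8%
- compound 3 `Cc1cccc(/C(N)=N/NC(=S)N2CCCCCC2)n1`: 38.8%

In a functional assay on MCF7 cells (Homo sapiens) for cytotoxicity, read by MTT assay, with a stated time of 72 h, tested at 30 uM (on this read-out higher numbers stand for more inhibition of growth at the one concentration tested and lower numbers for less inhibition of growth), compound 1 gives the highest of the three numbers. Compound 2 sits close to it, only a little lower and within the scatter, so the two cannot be told apart on this read-out. Compound 3 is well below, with a gap that lies beyond the scatter. Compound 4 `N/C(=N\NC(=S)N1CCOCC1)c1ccc(F)cn1` has not yet been measured. It differs from compound 1 in one place: morpholin-4-yl in place of pyrrolidin-1-yl on a thiocarbonyl carbon. Within the data shown here, no pair of measured compounds shows exactly this change on the same core, so the size of the step has to be judged from what the three measured compounds show. Compound 2, which carries morpholin-4-yl on a different core, gives 57.8%, close to compound 1. On that basis the step from compound 1 to compound 4 in this assay is expected to be small, within the scatter or slightly downward. Compound 4 is estimated at 55%, with a range from 38% to 70%, which means an expected step of a number 5.6 percentage points lower from compound 1 to compound 4 (within the scatter).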

Compound 4, percent growth inhibition at one concentration: 56.7%
Compound 4: middle estimate off by 1.7 percentage points, on the low side; the measured number falls inside the stated range.
By their numbers in this assay, from the lowest: compound 3; then compounds 4, 2 and 1 (each within the scatter of the next).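

In this assay the swap of morpholin-4-yl for pyrrolidin-1-yl on a thiocarbonyl carbon can now be read directly on one shared core, and it gives a number 3.9 percentage points lower from compound 1 to compound 4 (within the scatter) on that core. Compound 1 and compound 4 therefore cannot be told apart on this read-out, so at this place a five-membered ring with one hetero atom and a six-membered ring with two read alike. No measured evidence here bears on why the two rings read alike.

Going by these compounds, whether dimethylamino, which has no ring, or piperazin-1-yl, with a nitrogen in place of the morpholine oxygen, would read the same on this carbon stays open. A reading at one concentration also leaves open how compound 1 and compound 4 compare across a range of concentrations.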